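Dichlorophenyl isomers at the limit of a cytotoxicity read-out

This account rests on a few compounds, and the source may have more. Where it says the series, first, only, none or still open, it means among the compounds named here.

For the measured compounds named here, in a functional assay on MCF7 cells (Homo sapiens) for cytotoxicity, read by MTT assay, with a stated time of 72 h (a higher number here means a weaker inhibitor, a lower number a stronger inhibitor), compound 1 (`COc1cccc(/C=C2\CCC/C(=C\c3cccc(OC)c3OC)C2=O)c1`) gives 5900 nM, the only true number in this small set. Compound 2 (`COc1cccc(/C=C2\CCC/C(=C\c3cccc(Cl)c3Cl)C2=O)c1OC`) reaches only a limit, > 20000 nM. Compound 3 (`COc1cccc(/C=C2\CCC/C(=C\c3ccc(Cl)cc3Cl)C2=O)c1OC`) also reaches only a limit, > 20000 nM. Going by these compounds, compound 3 therefore stands at the limit of > 20000 nM in this assay, at which 2 of the 3 values shown sit, and its real value remains unknown.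

Compound 4 (`COc1cccc(/C=C2\CCC/C(=C\c3cc(Cl)cc(Cl)c3)C2=O)c1OC`) keeps the shared core and changes one group: 3,5-dichlorophenyl in place of 2,4-dichlorophenyl on a double-bonded chain carbon bound to a double-bonded ring carbon. In words, 3,5-dichlorophenyl takes the place of 2,4-dichlorophenyl on a double-bonded chain carbon bound to a double-bonded ring carbon.

Going by the values given here, three measured steps bear on this change. Leaving compound 1 for a dichlorophenyl compound gives an at least 3.3-fold higher number from compound 1 to compound 2 (0.53 log units; beyond the scatter), and likewise an at least 3.3-fold higher number from compound 1 to compound 3 (0.53 log units; beyond the scatter). Among the compounds with values here, the closest precedent, a swap between two dichlorophenyl groups, gives a step that the two limits leave unreadable from compound 2 to compound 3, so it cannot show how much the placing of the chlorines matters.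

With both measured dichlorophenyl compounds at the limit, no step beyond the scatter is expected in this assay, and a report of a limit alone is quite likely. The expected step is a number no higher from compound 3 to compound 4 (the limit leaves the size open). Compound 4 is estimated at 20000 nM, with an expected range of 9000 nM to 40000 nM.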

Compound 4, half-maximal inhibitory concentration: 4300 nM
Compound 4: the middle estimate sits 4.7-fold (0.67 log units) above what was measured; measured number outside the range, below it.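

The placing of the two chlorines matters in this assay, which the earlier pair of dichlorophenyl compounds could not show: 3,5-dichlorophenyl gives an at least 4.6-fold lower number from compound 3 to compound 4 (0.66 log units; beyond the scatter), and an at least 4.6-fold lower number from compound 2 to compound 4 (0.66 log units; beyond the scatter). The loss seen on leaving compound 1 is therefore not shared by every dichlorophenyl group, since the swap of 3-methoxyphenyl for 3,5-dichlorophenyl gives a 1.4-fold lower number from compound 1 to compound 4 (0.14 log units; within the scatter), and these two groups cannot be told apart in this read-out. Going by these compounds, the two steps from the other dichlorophenyl compounds show only a least size, and their full size stays open because both start from a limit: the limit of > 20000 nM in this assay, at which 2 of the 4 values shown sit.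

The compounds shown leave open whether the chlorine atoms themselves are needed, or whether 3,5-dimethylphenyl, 3,5-dimethoxyphenyl or a phenyl group carrying a single chlorine would hold the same level. They also leave open whether 3,5-dichlorophenyl would give the same result if the rest of the shared core were changed, for instance by an amine on the remaining phenyl group.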